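One Methoxy Group Removed: Expected Effect on Cell Growth

This account rests on a few compounds, and the source may have more. Where it says the series, first, only, none or still open, it means among the compounds named here.

Compound 2 `COc1ccc(-c2cc(/C=C/C(=O)c3ccc(N)cc3)[nH]n2)cc1OC` and compound 1 `COc1ccc(-c2cc(/C=C/C(=O)c3ccc(N)cc3)[nH]n2)cc1` differ by a single change, (hydrogen in place of methoxy on an aromatic carbon). In a functional assay on SN12C cells (Homo sapiens) for cytotoxicity, read by sulforhodamine B assay, with a stated time of 48 h, tested at 0.01 uM (a lower number here means a stronger effect, a higher number a weaker effect of the compound at the concentration tested), compound 2 gives 101%, and compound 1 gives 93%, a step of a number 8 percentage points lower from compound 2 to compound 1 (within the scatter). Compound 3 `COc1cc(C(=O)/C=C/c2cc(-c3cc(OC)c(OC)c(OC)c3)n[nH]2)cc(OC)c1OC` gives 96% in this assay; how its core differs from that of compound 2 is not broken down here. Compound 4 `COc1ccc(-c2cc(/C=C/C(=O)c3cc(OC)c(OC)c(OC)c3)[nH]n2)cc1OC` has not been measured yet; it differs from compound 3 by hydrogen in place of methoxy on an aromatic carbon. This is the same kind of change as from compound 2 to compound 1, though here the place is also meta to a methoxy group (2 heavy atoms). Given a number 8 percentage points lower from compound 2 to compound 1 (within the scatter), a similarly small step is expected here, a number 3 percentage points lower from compound 3 to compound 4 (within the scatter). Compound 4 is expected to give about 93%, with the likely range running from 80% to 105%.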

Compound 4, a percentage reported as activity, at one concentration (the size of the read-out at that concentration, not a potency): 98%
Estimate against measurement, compound 4: 5 percentage points below, and the stated range covers the measured number.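

In this assay the same swap of a methoxy group for hydrogen gives a number 2 percentage points higher from compound 3 to compound 4 (within the scatter) on this second core. Set beside the earlier step, the two cores show no difference in how they respond to the change: the same change on two cores in this assay, a number 8 percentage points lower (within the scatter) from compound 2 to compound 1 and a number 2 percentage points higher (within the scatter) from compound 3 to compound 4, 10 percentage points apart, within the scatter of two such steps. Neither step stands clear of the scatter, so this does not show that the change has any effect on either core, nor that an effect of the same size would carry from one core to the other; it shows only that none can be seen at this one concentration.

Still open, on these data alone, is whether another group in this place, such as an amine, a hydroxyl or a longer alkoxy chain, would move the read-out.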